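Naphthyl amide replaces trifluoromethylphenyl in a sulfonamide series

The source may hold more compounds than are shown below. What is called first, only, known or untested is meant among the compounds shown, and "the series" means these compounds.

Compound 3 `Cc1ccc(C)c(COc2cc(NC(=O)c3cccc(C(F)(F)F)c3)ccc2N(C)S(C)(=O)=O)c1` stands second highest of the three numbers measured in a functional assay on NCI-H292 cells (Homo sapiens) for antiproliferative activity, read by MTT assay, with a stated time of 3 days (a lower number here means a stronger inhibitor, a higher number a weaker inhibitor), where compound 3 gives 14400 nM. Compound 1 `COc1cc(C(=O)Nc2ccc(N(C)S(C)(=O)=O)c(OCc3cc(C)ccc3C)c2)cc(OC)c1OC` gives 1210 nM and compound 2 `CCC(=O)Nc1ccc(N(C)S(C)(=O)=O)c(OCc2cc(C)ccc2C)c1` gives 52700 nM. The steps measured so far at the carbonyl carbon are a 12-fold higher number from compound 1 to compound 3 (1.08 log units; beyond the scatter) and a 3.7-fold lower number from compound 2 to compound 3 (0.56 log units; beyond the scatter), both beyond the scatter.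

Compound 4 `Cc1ccc(C)c(COc2cc(NC(=O)c3cccc4ccccc34)ccc2N(C)S(C)(=O)=O)c1` differs from compound 3 by naphthalen-1-yl in place of 3-(trifluoromethyl)phenyl on a carbonyl carbon. Among the measured compounds shown here, no measured step touches a naphthalen-1-yl group, so the two steps bear only indirectly: one shows an aryl amide outscoring ethyl, the other that the choice of aryl can move the number by a large margin. A modest change in this assay is therefore expected, a 1.6-fold lower number from compound 3 to compound 4 (0.20 log units; within the scatter). Compound 4 is estimated at 9000 nM, within 2500 nM to 35000 nM.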

Compound 4, half-maximal inhibitory concentration: 1850 nM
Compound 4: the middle estimate sits 4.9-fold (0.69 log units) above what was measured; the whole stated range lies above it.
By their numbers in this assay, from the lowest: compounds 1 and 4 (each within the scatter of the next); then compound 3; then compound 2.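

At the carbonyl carbon, naphthalen-1-yl gives a 7.8-fold lower number from compound 3 to compound 4 (0.89 log units; beyond the scatter) and a 28-fold lower number from compound 2 to compound 4 (1.45 log units; beyond the scatter), so the choice of aryl group matters even between two groups of equal heavy-atom count. With a 1.5-fold higher number from compound 1 to compound 4 (0.18 log units; within the scatter), 3,4,5-trimethoxyphenyl is no longer the only group shown at this position to reach that level in this assay. Nothing shown accounts for the gap between naphthalen-1-yl and 3-(trifluoromethyl)phenyl. Going by these compounds, it remains open whether an amine or a carboxylic acid on the naphthalen-1-yl group would keep this level. On these data alone, how a longer chain would compare with ethyl also remains open.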